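Two inverted ring stereocentres in a well-tolerated series

The compounds below may be only part of what the source reports. "The series", "measured", "known", "first", "only" and "open" are said of these compounds alone.

In an ADME assay on Huh-7 cells (Homo sapiens) for cytotoxicity (a lower number here means that less compound is tolerated, a higher number that more compound is tolerated), compound 1 (`COC(=O)N[C@@H](C(=O)N1CC(=O)C[C@H]1C(=O)Nc1ccc(-c2ccc(NC(=O)[C@@H]3CC(=O)CN3C(=O)[C@H](NC(=O)OC)c3ccccc3)cc2)cc1)c1ccccc1`) gives > 25000 nM, which is a limit of the assay and not a number. Compound 2 (`COC(=O)N[C@@H](C(=O)N1CCCC[C@H]1C(=O)Nc1ccc(-c2ccc(NC(=O)[C@@H]3CCCCN3C(=O)[C@H](NC(=O)OC)c3ccccc3)cc2)cc1)c1ccccc1`) gives > 25000 nM, which is also a limit and not a number. Compound 2 therefore stands at the limit of > 25000 nM in this assay, at which 2 of the 2 values shown sit. Going by the values given here, these two results allow no ordering, and the series offers no measured step to use as a guide.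

Compound 3 (`COC(=O)N[C@@H](C(=O)N1CCCC[C@@H]1C(=O)Nc1ccc(-c2ccc(NC(=O)[C@H]3CCCCN3C(=O)[C@H](NC(=O)OC)c3ccccc3)cc2)cc1)c1ccccc1`) has the same atoms and bonds as compound 2 and differs only in configuration as drawn (the two compounds have the same atoms and bonds and differ only in configuration as drawn: 2 of 4 stereo elements differ; a stereocentre at a saturated ring carbon is drawn S in compound 2 and R in compound 3; a stereocentre at a saturated ring carbon is drawn S in compound 2 and R in compound 3). A stereocentre at a saturated ring carbon is drawn S in compound 2 and R in compound 3, and the same holds for a second such stereocentre.

In this assay no step beyond the usual scatter is expected, in either direction. This expectation rests mainly on compound 2, whose result of > 25000 nM is a limit. The estimated step is a number no higher from compound 2 to compound 3 (the limit leaves the size open). A report of only a limit is the likeliest outcome, and the estimate for compound 3 is 25000 nM, with an expected range of 10000 nM to 50000 nM.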

Compound 3, half-maximal cytotoxic concentration: > 25000 nM
Compound 3 gave a limit, no number; the forecaster's own chance of this, stated with the estimate: 85%; the middle value lies on the limit itself.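

In this assay compound 3 gives > 25000 nM, a limit and not a number. Going by these compounds alone, compound 2 also rests on a limit, so no step between compound 2 and compound 3 can be read. The compounds shown leave open the concentration at which any of them becomes cytotoxic, and whether inverting the two ring stereocentres alters it.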